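A few compounds are considered here, and "the series" means these few. Any claim that something is new, unique, unknown or untested is made for them only; others in the source may bear on it.

Measured compounds:
compound 1 `COc1ccccc1-c1ncnn1-c1cc(OC)c(OC)c(OC)c1` — in a functional assay on Jurkat cells (Homo sapiens) for antiproliferative activity, read by MTT assay, with a stated time of 72 h (on this read-out lower numbers stand for stronger inhibition and higher numbers for weaker inhibition), compound 1 gives > 10000 nM, a limit of the assay.
compound 2 `COc1cc(-c2ncnn2-c2cccc(N)c2)cc(OC)c1OC` — compound 2 gives > 10000 nM, again only a limit.
compound 3 `COc1cc(-n2ncnc2-c2ccc(F)cc2)cc(OC)c1OC` — compound 3 gives > 10000 nM, also a limit.

Compound 2 thus stands at a limit, and the two further values shown are limits too; the limit of > 10000 nM in this assay, at which 3 of the 3 values shown sit, sums up the whole set. Among the compounds with values here, the single one-place step between measured compounds, a step that the two limits leave unreadable from compound 1 to compound 3, cannot be read, as both ends are limits.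

Compound 4 `COc1cc(-c2ncnn2-c2ccc(Cl)cc2Cl)cc(OC)c1OC` differs from compound 2 in a single place: 2,4-dichlorophenyl in place of 3-aminophenyl on an aromatic nitrogen. Within the data shown here, no measured step exercises this change; the only step available, a step that the two limits leave unreadable from compound 1 to compound 3, concerns a different position and is itself unreadable. With all three measured values at the limit, there is no basis to expect compound 4 to move into the readable range, and the expected step from compound 2, a step that the limit leaves unreadable from compound 2 to compound 4, starts from a limit and is expected to end at one as well. Compound 4 is therefore estimated at 15000 nM, with a range from 3000 nM to 100000 nM, and most likely reported only as a limit.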

Compound 4, half-maximal inhibitory concentration: > 10000 nM
Compound 4: only a limit was reported (the forecaster's own chance of this, stated with the estimate: 75%); the middle value is on the limit's open side.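

The step from compound 2 to compound 4 cannot be read, as both ends are limits in this assay. The whole set stands at one limit: the limit of > 10000 nM in this assay, at which 4 of the 4 values shown sit.

The compounds shown leave open which change on the shared core, if any, gives a readable value in this assay.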